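Chain extension on the triazole of compound 3

The source may report more compounds than this note shows. Statements on the series, on what has been measured and on what is new or still open speak of the compounds shown alone.

Measured in a functional assay on MCF7 cells (Homo sapiens) for inhibition, read by MTT assay; on this read-out lower numbers stand for stronger inhibition and higher numbers for weaker inhibition:
compound 1 `CCCCCCCCn1cc(/C=C/C(=O)c2ccc(NC(=O)CN3CCN(c4ccccc4)CC3)cc2)nn1`: 31900 nM
compound 2 `CCCCCCCCn1cc(/C=C/C(=O)c2ccc(NC(=O)CN3CCN(C(=O)OC(C)(C)C)CC3)cc2)nn1`: 98400 nM
compound 3 `CCCCCCCCn1cc(/C=C/C(=O)c2ccc(NC(=O)CN3CCN(c4ccc([N+](=O)[O-])cc4)CC3)cc2)nn1`: 49100 nM

Compound 3 sits close to both neighbours in this assay: a 1.5-fold higher number from compound 1 to compound 3 (0.19 log units; within the scatter) and a 2.0-fold lower number from compound 2 to compound 3 (0.30 log units; within the scatter) are both inside the scatter, so no order among these three compounds can be read off, apart from a 3.1-fold higher number from compound 1 to compound 2 (0.49 log units; beyond the scatter).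

Compound 4 `CCCCCCCCCCn1cc(/C=C/C(=O)c2ccc(NC(=O)CN3CCN(c4ccc([N+](=O)[O-])cc4)CC3)cc2)nn1` differs from compound 3 only in ethyl in place of hydrogen on a saturated chain carbon, eight bonds along the chain from an aromatic nitrogen. Going by the values given here, none of the measured steps touches the chain on the triazole; all three vary the group on the piperazine nitrogen, so nothing in this assay bears on the change. Among the compounds with values here, with no precedent, no step beyond the scatter is expected: a 1.0-fold lower number from compound 3 to compound 4 (0.00 log units; within the scatter). Compound 4 is therefore estimated at 49000 nM, with a range of 15000 nM to 160000 nM.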

Compound 4, half-maximal inhibitory concentration: 44400 nM
Estimate against measurement, compound 4: 1.1-fold (0.04 log units) above; measured number inside the range.
By their numbers in this assay, from the lowest: compounds 1, 4, 3 and 2 (each within the scatter of the next, the first and the last beyond it).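

Going by these compounds alone, the chain on the triazole is varied here for the first time: in this assay, ethyl in place of hydrogen on a saturated chain carbon, eight bonds along the chain from an aromatic nitrogen, gives a 1.1-fold lower number from compound 3 to compound 4 (0.04 log units; within the scatter), so this read-out does not separate the two chain lengths. This holds only with 4-nitrophenyl on the piperazine nitrogen. Nothing available accounts for this result.

From the compounds shown here alone, whether the same holds with phenyl or tert-butoxycarbonyl on that nitrogen stays open. Also open, going by these compounds, is how a shorter butyl chain, or a chain ending in an amine or a carboxylic acid, would read.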